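This account rests on a few compounds, and the source may have more. Where it says the series, first, only, none or still open, it means among the compounds named here.

Compound 1 `COc1cc(C(c2ccc(O)c(OC)c2)[C@@H](C)[C@H](C)CF)ccc1O` and compound 2 `COc1ccc(C(c2ccc(OC)c(OC)c2)[C@H](C)[C@@H](C)CO)cc1OC` share a core and differ in several places at once. In a functional assay on HeLa cells (Homo sapiens) for cytotoxicity, read by WST assay, with a stated time of 48 h (on this read-out lower numbers stand for stronger inhibition and higher numbers for weaker inhibition), compound 1 gives 37000 nM, and compound 2 gives 67000 nM; the two numbers lie within the scatter of each other, so neither stands apart. Compound 3 `COC[C@H](C)[C@H](C)C(c1ccc(O)c(OC)c1)c1ccc(O)c(OC)c1` has not yet been measured. It differs from compound 1 by 1-(methoxymethyl)ethyl in place of 1-(fluoromethyl)ethyl on a saturated chain carbon bound to two saturated chain carbons. For the measured compounds named here, no measured pair shows this change, so no step beyond the scatter is expected in this assay. Compound 3 is estimated at 40000 nM, between 15000 nM and 100000 nM. This corresponds to an expected step of a 1.1-fold higher number from compound 1 to compound 3 (0.03 log units; within the scatter).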

Compound 3, half-maximal inhibitory concentration: 72000 nM
Compound 3: middle estimate off by 1.8-fold (0.26 log units), on the low side, and the stated range covers the measured number.
By their numbers in this assay, from the lowest: compounds 1, 2 and 3 (each within the scatter of the next).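

In this assay, for the compounds shown here, 1-(methoxymethyl)ethyl in place of 1-(fluoromethyl)ethyl on a saturated chain carbon bound to two saturated chain carbons gives a 1.9-fold higher number from compound 1 to compound 3 (0.29 log units; within the scatter) and so offers the first direct reading of a change at this position. Going by these compounds alone, at this place, exchanging the fluorine-bearing group for the methoxy-bearing one, which brings a hydrogen-bond acceptor, gives no step that stands out from the scatter. No measured evidence here bears on why. Going by these compounds, whether an amine or a longer chain at this place would shift the number remains open.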